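The compounds below may be only part of what the source reports. "The series", "measured", "known", "first", "only" and "open" are said of these compounds alone.

Compound 1, `O=C1O/C(=C\Cn2cc(Cc3ccccc3)nn2)C(OCc2ccccc2)=C1OCc1ccccc1`: > 100000 nM
Compound 2, `O=C1NC(O)(CCn2cc(C3=CCCCC3)nn2)C(OCc2ccccc2)=C1OCc1ccccc1`: > 100000 nM

In a functional assay on U-937 cells (Homo sapiens) for antiproliferative activity, read by MTT assay, with a stated time of 24 h (a lower number here means a stronger inhibitor, a higher number a weaker inhibitor), compound 1 gives > 100000 nM. That figure is a limit of the assay rather than a measured number. Compound 2, which shares the same two benzyloxy groups on its core, also reaches only a limit in this assay, > 100000 nM. So compound 1 stands at the limit of > 100000 nM in this assay, at which 2 of the 2 values shown sit, and nothing in the numbers shown separates it from compound 2 or places either one on a measurable scale.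

Compound 3, `CC(C)(C)c1ccc(-c2cn(C/C=C3\OC(=O)C(OCc4ccccc4)=C3OCc3ccccc3)nn2)cc1`, is the next compound to be tested. It differs from compound 1 in a single place: 4-(tert-butyl)phenyl in place of benzyl on an aromatic carbon. Within the data shown here, no step between two measured compounds is available to show what such a swap does in this assay. With both measured compounds sitting at the limit, the expectation is that compound 3 will also show no activity beyond the scatter, and the step that the limit leaves unreadable from compound 1 to compound 3 is expected to be essentially flat. Compound 3 is therefore estimated at 150000 nM, with a range from 30000 nM to 600000 nM, most likely reported again only as a limit.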

Compound 3, half-maximal inhibitory concentration: > 100000 nM
Compound 3 was reported as a limit; the forecaster's own chance of this, stated with the estimate: 75%; the middle value does not contradict the limit.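

No step can be read from compound 1 to compound 3, as both results are limits rather than measured numbers, and the same holds for all compounds shown: the limit of > 100000 nM in this assay, at which 3 of the 3 values shown sit.

The compounds shown leave open which change to the shared core, if any, would give a measurable value.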